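A few compounds are considered here, and "the series" means these few. Any claim that something is new, unique, unknown or untested is made for them only; others in the source may bear on it.

Working notes on the series.

Compound 1 `O=C1[C@@H](NS(=O)(=O)c2ccc(-c3ccon3)s2)CCN1Cc1cc2c[nH]ccc-2n1` is the reference point: in an assay on isolated protein for inhibition of coagulation factor X (Oryctolagus cuniculus), tested at 1 uM (on this read-out lower numbers stand for less inhibition and higher numbers for more inhibition at the one concentration tested (going by the name of the read-out)), compound 1 gives 17%. Among the compounds with values here, compound 2 `O=C1[C@@H](NS(=O)(=O)c2ccc(-c3ccon3)s2)CCN1Cc1cc2cc[nH]cc-2n1` carries the change a group of 9 heavy atoms (7 carbon, 2 nitrogen; one five-membered aromatic ring with 1 hetero atom, one six-membered aromatic ring with 1 hetero atom) in place of a group of 9 heavy atoms (7 carbon, 2 nitrogen; one five-membered aromatic ring with 1 hetero atom, one six-membered aromatic ring with 1 hetero atom), on a saturated chain carbon bound to an amide-type nitrogen in a ring and in this assay compound 2 gives 49%; the step of a number 32 percentage points higher from compound 1 to compound 2 (beyond the scatter) is the only measured instance of this change so far.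

Compound 3 `Cc1c(S(=O)(=O)N[C@H]2CCN(Cc3cc4c[nH]ccc-4n3)C2=O)sc2ccc(Cl)cc12` sits on a different core; the difference between the core of compound 3 and the core of compound 1 is not broken down here. In this assay compound 3 gives 37%, which places it between compound 1 and compound 2.

Compound 4 `Cc1c(S(=O)(=O)N[C@H]2CCN(Cc3cc4cc[nH]cc-4n3)C2=O)sc2ccc(Cl)cc12` is not yet measured. It differs from compound 3 by a group of 9 heavy atoms (7 carbon, 2 nitrogen; one five-membered aromatic ring with 1 hetero atom, one six-membered aromatic ring with 1 hetero atom) in place of a group of 9 heavy atoms (7 carbon, 2 nitrogen; one five-membered aromatic ring with 1 hetero atom, one six-membered aromatic ring with 1 hetero atom), on a saturated chain carbon bound to an amide-type nitrogen in a ring, the same change as from compound 1 to compound 2, at a place described in the same words, so it counts as the same kind of change on a second core.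

Beside the earlier step of a number 32 percentage points higher from compound 1 to compound 2 (beyond the scatter), the step from compound 3 to compound 4 is expected to be a number 25 percentage points higher from compound 3 to compound 4 (beyond the scatter) in this assay; this rests on a single prior instance, so the transfer is uncertain, and compound 3 starts from 37%. For compound 4 the estimate in this assay is 62%, with a range from 45% to 80%.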

Compound 4, a percentage reported as inhibition, at one concentration (the size of the read-out at that concentration, not a potency): 52%
The estimate for compound 4 lay 10 percentage points above the measured number, and the stated range covers the measured number.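

On the core of compound 3, the change gives a number 15 percentage points higher from compound 3 to compound 4 (beyond the scatter) in this assay, so its direction carries over from the core of compound 1. The size of the step does not carry over unchanged: the same change on two cores in this assay, a number 32 percentage points higher (beyond the scatter) from compound 1 to compound 2 and a number 15 percentage points higher (beyond the scatter) from compound 3 to compound 4, 17 percentage points apart, beyond the scatter of two such steps. With only two instances, this shows neither a typical size for the step on other cores nor the reason the two steps differ, and the same direction on two cores does not establish a rule for the series.

Still open, from the compounds shown here alone, is whether the change gives a step in the same direction on a third core, and whether an amine or a carboxylic acid added to the group that enters would keep the higher number on either core. Since each number is a percentage at a single concentration, the compounds shown also leave open how the steps would look as differences in potency.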